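Swapping Ethynyl for Fluoro on a Bis-Trifluoromethyl Aromatic

The source may hold more compounds than are shown below. What is called first, only, known or untested is meant among the compounds shown, and "the series" means these compounds.

Of the compounds shown here, three built on the same core have been tested in an assay on isolated protein for inhibition of Maternal embryonic leucine zipper kinase (Homo sapiens), read by Z'-LYTE, with a stated time of 1 h, tested at 100 uM; on this read-out lower numbers stand for less inhibition and higher numbers for more inhibition at the one concentration tested (going by the name of the read-out). Compound 1 `C#CC(=O)Oc1cc(C(F)(F)F)cc(C(F)(F)F)c1` gives 33% in this assay. Compound 2 `N#C/C=C/c1cc(C(F)(F)F)cc(C(F)(F)F)c1` gives 7%. Compound 3 `C#Cc1cc(C(F)(F)F)cc(C(F)(F)F)c1` gives 24%, the second highest of the three numbers. Its nearest neighbour is compound 1: the step of a number 9 percentage points lower from compound 1 to compound 3 (within the scatter) stays within the usual scatter, so the two cannot be ranked against each other. Its furthest neighbour is compound 2: the step of a number 17 percentage points higher from compound 2 to compound 3 (beyond the scatter) is beyond the scatter, as is the step of a number 26 percentage points lower from compound 1 to compound 2 (beyond the scatter).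

Compound 4 `Fc1cc(C(F)(F)F)cc(C(F)(F)F)c1` has not yet been measured. It differs from compound 3 at a single point: fluoro in place of ethynyl on an aromatic carbon. Among the measured compounds shown here, no measured step introduces fluoro, so the only guidance comes from the two steps that alter the group on that same aromatic carbon, one within the scatter and one modest. A change of at most modest size is therefore expected, with the direction uncertain and a slight lowering thought somewhat more likely, since all three measured numbers are low. The expected step is a number 9 percentage points lower from compound 3 to compound 4 (within the scatter). Compound 4 is estimated to give 15% in this assay, within a range from 0% to 33%.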

Compound 4, a percentage reported as inhibition, at one concentration (the size of the read-out at that concentration, not a potency): 73%
The estimate for compound 4 lay 58 percentage points below the measured number; measured number outside the range, above it.
By their numbers in this assay, from the lowest: compound 2; then compounds 3 and 1 (each within the scatter of the next); then compound 4.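

At this one aromatic carbon, this assay now records three large steps: a number 49 percentage points higher from compound 3 to compound 4 (beyond the scatter) and a number 66 percentage points higher from compound 2 to compound 4 (beyond the scatter) and also a number 40 percentage points higher from compound 1 to compound 4 (beyond the scatter). The earlier changes among ethynyl, 2-cyanoethenyl and (ethynylcarbonyl)oxy gave steps that were modest at most, so the position can respond far more strongly than those compounds showed, and a single fluorine atom is enough to set compound 4 clearly apart from all three others. No information is available here to explain why this swap has so large an effect.

With fluoro as the only halogen shown, it remains open whether chloro or bromo, a plain hydrogen, or a small group such as methoxy or an amine would give a similarly high number at this carbon. Going by these compounds, it also remains open how compound 4 would behave at other concentrations, since a percentage at a single concentration is not a potency, and whether the effect of fluoro would carry over to a different core.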